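Swapping fluoro for chloro on an inactive sulfonate ester series

The compounds below may be only part of what the source reports. "The series", "measured", "known", "first", "only" and "open" are said of these compounds alone.

Compound 1 `CN1CCN(c2ccc(S(=O)(=O)Oc3ccc(F)cc3)cc2)C1=O` carries a 4-fluorophenoxy ester on a shared core. In a functional assay on MCF7 cells (Homo sapiens) for antiproliferative activity, read by sulforhodamine B assay, with a stated time of 48 h (on this read-out higher numbers stand for weaker inhibition and lower numbers for stronger inhibition), compound 1 gives only a limit, > 100000 nM. Compound 2 `CN1CCN(c2ccc(S(=O)(=O)Oc3ccc(Cl)cc3)cc2)C1=O` differs from it by chloro in place of fluoro on an aromatic carbon. In this assay compound 2 likewise gives only a limit, > 100000 nM. The step that the two limits leave unreadable from compound 1 to compound 2 therefore cannot be read, because both values sit at the limit of > 100000 nM in this assay, at which 3 of the 3 values shown sit.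

Compound 3 `CCN1CCN(c2ccc(S(=O)(=O)Oc3cccc(F)c3)cc2)C1=O` has a different core; how it differs from compound 1 is not broken down here. In this assay compound 3 also gives only a limit, > 100000 nM.

Compound 4 `CCN1CCN(c2ccc(S(=O)(=O)Oc3cccc(Cl)c3)cc2)C1=O` is not yet measured. It differs from compound 3 by chloro in place of fluoro on an aromatic carbon, the same kind of change as from compound 1 to compound 2, though there the chloro sat para to a large group and here meta. With every shown value at the limit of > 100000 nM in this assay, at which 3 of the 3 values shown sit, the step that the limit leaves unreadable from compound 3 to compound 4 is expected to be unreadable. Compound 4 is estimated at 150000 nM, most likely again only a limit.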

Compound 4, half-maximal inhibitory concentration: 5400 nM
Estimate against measurement, compound 4: 28-fold (1.44 log units) above; measured number below the stated range.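

The step of an at least 18-fold lower number from compound 3 to compound 4 (1.26 log units; beyond the scatter) in this assay shows that, on the core of compound 3, chloro in place of fluoro matters a great deal. Compound 2 gives > 100000 nM as a limit, so the same swap on the core of compound 1 cannot be read, and the gain is shown on one core only, not as a change that carries from core to core. The chloro of compound 4 also sits meta to a large group, unlike that of compound 2, so core and position cannot be told apart here.

The compounds shown leave open whether 3-chlorophenoxy on the core of compound 1 would give a readable number. They also leave open whether bromo in that place would match chloro.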